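The compounds below may be only part of what the source reports. "The series", "measured", "known", "first", "only" and "open" are said of these compounds alone.

In an ADME assay (liver) for metabolic stability, with Liver microsome (Homo sapiens) as the target, read by LC-MS, using microsomes and NADPH, with a stated time of 5 min, at 37 degrees C (on this read-out higher numbers stand for fast clearance and lower numbers for slow clearance), compound 1 `CCn1c([C@@H](C)NS(=O)(=O)c2ccc(Cl)cc2)nc2cc(CO)ccc21` gives 88 mL.min-1.g-1, compound 2 `CCn1c(C(C)NS(=O)(=O)c2ccc(Cl)cc2)nc2ncccc21` gives 15 mL.min-1.g-1 and compound 3 `CCn1c([C@@H](C)NS(=O)(=O)c2ccc(F)cc2)nc2ccc(C(F)(F)F)cc21` gives 26 mL.min-1.g-1. Compound 3 therefore lies within the usual scatter of compound 2, while compound 1 stands clearly higher than compound 3, beyond that scatter. Compound 4 `CCn1c([C@@H](C)NS(=O)(=O)c2c(F)cc(F)cc2F)nc2ccc(C(F)(F)F)cc21` has 2,4,6-trifluorophenyl in place of 4-fluorophenyl on a sulfonyl sulfur. Among the compounds with values here, no pair of measured compounds shows a swap of this kind, so the data offer no direct guide to its size. The expected step in this assay, a 1.1-fold lower number from compound 3 to compound 4 (0.03 log units; within the scatter), is none beyond the scatter. Compound 4 is estimated at 24 mL.min-1.g-1, with an expected range of 11 mL.min-1.g-1 to 52 mL.min-1.g-1.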

Compound 4, intrinsic clearance in microsomes: 19 mL.min-1.g-1
Estimate against measurement, compound 4: 1.3-fold (0.10 log units) above; measured number inside the range.
By their numbers in this assay, from the lowest: compounds 2, 4 and 3 (each within the scatter of the next); then compound 1.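

In this assay, within the data shown here, placing 2,4,6-trifluorophenyl instead of 4-fluorophenyl on the sulfonyl sulfur gives a first direct reading at this position (a 1.4-fold lower number from compound 3 to compound 4 (0.14 log units; within the scatter)). The added fluorine atoms therefore leave clearance indistinguishable between these two compounds. No measurement here offers an explanation for this result. Still open, as far as these compounds go, is how a phenyl ring carrying an amine or a carboxylic acid would behave on the sulfonyl sulfur, or a saturated cyclohexyl group in place of the ring. From the compounds shown here alone, the same swap on the core of compound 1 or compound 2 also remains open.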